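The source may hold more compounds than are shown below. What is called first, only, known or untested is meant among the compounds shown, and "the series" means these compounds.

Working notes on the series. Going by the values given here, compound 1 `C/N=C(\S)n1ncnc1N` is the unsubstituted parent; in a functional assay on the whole organism for inhibition, with Rattus norvegicus as the target, at a dose of 30 mg/kg (on this read-out lower numbers stand for less inhibition and higher numbers for more inhibition at the one dose given (going by the name of the read-out)), compound 1 gives 93%, the highest of the three numbers measured so far, with compound 3 nearest and compound 2 furthest. Compound 2 `CCCC/N=C(\S)n1ncnc1N` carries propyl in place of hydrogen on a saturated chain carbon bound to a double-bonded nitrogen, and in this assay compound 2 gives 21%, so the step of a number 72 percentage points lower from compound 1 to compound 2 (beyond the scatter) is large and well beyond the scatter. Among the compounds with values here, compound 3 `Nc1ncnn1/C(S)=N/C1CCCCC1` in this assay gives 31%, again far below the number of compound 1 and beyond the scatter, though no single-point step links these two.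

Compound 4 `Nc1ncnn1/C(S)=N/CCCCCO` is the next compound for this assay. It differs from compound 1 by 4-hydroxybutyl in place of hydrogen on a saturated chain carbon bound to a double-bonded nitrogen. Within the data shown here, the one measured step that bears directly on this change is a number 72 percentage points lower from compound 1 to compound 2 (beyond the scatter), a large fall when a chain entered at the same place; the low number of compound 3 points the same way. A large downward step is therefore expected, a number 58 percentage points lower from compound 1 to compound 4 (beyond the scatter), and for compound 4 the number in this assay is estimated at 35%, within a range of 10% to 65%. Among the measured compounds shown here, compound 1 is the only compound in the set that keeps a high number, so no case yet contradicts this expectation.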

Compound 4, a percentage reported as inhibition, in the whole organism at one dose (the size of the read-out at that dose, not a potency): -17%
Compound 4: the middle estimate sits 52 percentage points above what was measured; the whole stated range lies above it.
By their numbers in this assay, from the lowest: compound 4; then compounds 2 and 3 (each within the scatter of the next); then compound 1.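

In this assay, going by these compounds alone, the place on a saturated chain carbon bound to a double-bonded nitrogen now holds a second open chain, 4-hydroxybutyl, and the outcome is a number 110 percentage points lower from compound 1 to compound 4 (beyond the scatter), with compound 4 the only member of the series to give a negative number. The loss at this place does not stop at the low level of compound 2: hydroxymethyl in place of hydrogen on a saturated chain carbon, four bonds along the chain from a double-bonded nitrogen, gives a number 38 percentage points lower from compound 2 to compound 4 (beyond the scatter), so a change at the far end of the chain still moves the number. No measurement at hand gives a reason for either step.

The change from compound 2 to compound 4 adds carbon and oxygen together, so the compounds shown do not separate the effect of chain length from that of the terminal hydroxyl; a plain pentyl chain would part the two. Also open, on these data alone, is whether a shorter chain such as 2-hydroxyethyl, or a chain ending in an amine or a carboxylic acid, would fall as far.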